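Replacing the Nitrile of Compound 1 with an Acetamide

A few compounds are considered here, and "the series" means these few. Any claim that something is new, unique, unknown or untested is made for them only; others in the source may bear on it.

Compound 1 `C/N=C(/S)[C@@]1(c2cccnc2)CCCC[C@@H]1CC#N` gives 300 nM in a functional assay (aorta) with Rattus norvegicus as the target (a higher number here means a weaker inhibitor, a lower number a stronger inhibitor), the higher of the two measured numbers. Compound 2 `C/N=C(/S)[C@@]1(c2cccnc2)CCCC[C@@H]1C/C=N/OCc1ccccc1`, the other measured compound, gives 30 nM in this assay, a lower number beyond the scatter. Compound 3 `C/N=C(/S)[C@@]1(c2cccnc2)CCCC[C@@H]1CCNC(C)=O` has not yet been measured; it differs from compound 1 by acetamidomethyl in place of cyano on a saturated chain carbon bound to a saturated ring carbon. The result for compound 2, 30 nM, shows that a larger group in place of cyano can go with a lower number, so a small step toward lower numbers is expected from compound 1 to compound 3, a 1.5-fold lower number from compound 1 to compound 3 (0.18 log units; within the scatter), possibly within the scatter. Compound 3 is expected to give about 200 nM, between 50 nM and 1000 nM.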

Compound 3, concentration for 90% inhibition: 130 nM
Beside the measured number, compound 3's estimate is 1.5-fold (0.19 log units) above it, within the range that was stated.
By their numbers in this assay, from the lowest: compound 2; then compound 3; then compound 1.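

In this assay acetamidomethyl in place of cyano on a saturated chain carbon bound to a saturated ring carbon gives a 2.3-fold lower number from compound 1 to compound 3 (0.36 log units; beyond the scatter) and so a modest step. The position thus accepts a group with one hydrogen-bond donor, which cyano does not have, and the number still falls. Nothing at hand explains this step. The compounds shown leave open whether the amide hydrogen matters, and how a primary amine, a carboxylic acid or a longer chain ending in the same acetamide would read at this position.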